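This account rests on a few compounds, and the source may have more. Where it says the series, first, only, none or still open, it means among the compounds named here.

Compound 1, `COc1cc(N)c(Cl)cc1C(=O)CCC1CCN(CCNS(=O)(=O)c2ccc(C)cc2)CC1`: 15% in an assay on HEK293 cells for displacement of a labelled ligand from 5-hydroxytryptamine receptor 6 (Homo sapiens), with a stated time of 60 min, tested at 1 uM, in the presence of a further agent that is not named here; on this read-out higher numbers stand for a stronger effect at the one concentration tested and lower numbers for a weaker effect
Compound 2, `COc1cc(N)c(Cl)cc1C(=O)CCC1CCN(CCNS(=O)(=O)c2ccc(NC(C)=O)cc2)CC1`: 67%

For the measured compounds named here, on these two numbers compound 1 stands lowest; its only neighbour, compound 2, lies a number 52 percentage points higher from compound 1 to compound 2 (beyond the scatter) away, a large step beyond the scatter. Compound 3, `COc1ccc(S(=O)(=O)NCCN2CCC(CCC(=O)c3cc(Cl)c(N)cc3OC)CC2)c(OC)c1`, has not been measured. Its difference from compound 1 is 2,4-dimethoxyphenyl in place of 4-methylphenyl on a sulfonyl sulfur. Going by the values given here, the one measured step also changed this same aromatic ring and showed that its substituents can move the read-out strongly, yet it involved a different group, so it gives only loose guidance. A moderate rise is therefore expected, a number 20 percentage points higher from compound 1 to compound 3 (beyond the scatter). Compound 3 is estimated at 35%, within 10% to 65%.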

Compound 3, a percentage reported as inhibition, at one concentration (the size of the read-out at that concentration, not a potency): 45%
For compound 3 the middle estimate is 10 percentage points below the measured one; low and high end bracket the measured number.
By their numbers in this assay, from the lowest: compound 1; then compound 3; then compound 2.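

In this assay, replacing 4-methylphenyl on the sulfonyl sulfur with 2,4-dimethoxyphenyl gives a number 30 percentage points higher from compound 1 to compound 3 (beyond the scatter), so the rise is not unique to 4-acetamidophenyl. The two raising groups are also not equal: replacing 4-acetamidophenyl with 2,4-dimethoxyphenyl gives a number 22 percentage points lower from compound 2 to compound 3 (beyond the scatter), which shows that this position separates them too. No available evidence explains these differences. From the compounds shown here alone, it remains open whether 4-methoxyphenyl or 2-methoxyphenyl alone would carry the rise, and how a ring bearing an amine or a carboxylic acid would read.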